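From Thiophen-2-yl to 2,4,6-Trimethylphenyl in a Weak Series

The source may report more compounds than this note shows. Statements on the series, on what has been measured and on what is new or still open speak of the compounds shown alone.

Of the compounds shown here, three sharing one core have been tested so far. In a functional assay on MCF7 cells (Homo sapiens) for inhibition, read by MTT assay, with a stated time of 48 h (on this read-out lower numbers stand for stronger inhibition and higher numbers for weaker inhibition), compound 1 (`O=C(CC(c1ccccc1)C(C(=O)Nc1ccccn1)C(=O)Nc1ccccn1)c1ccc(F)cc1`) is reported as "not active" (no number reported) here. In this assay compound 2 (`O=C(CC(c1cccs1)C(C(=O)Nc1ccccn1)C(=O)Nc1ccccn1)c1ccccc1`) is also reported as "not active" (no number reported) and so has no number of its own. It stands with compound 1, without an exact position on the scale. Only compound 3 (`O=C(CC(c1ccc(Cl)cc1)C(C(=O)Nc1ccccn1)C(=O)Nc1ccccn1)c1ccc2ccccc2c1`) gives a number, 50000 nM in this assay as its result.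

Compound 4 (`Cc1cc(C)c(C(CC(=O)c2ccccc2)C(C(=O)Nc2ccccn2)C(=O)Nc2ccccn2)c(C)c1`) has not yet been measured. The structural change is 2,4,6-trimethylphenyl in place of thiophen-2-yl on a saturated chain carbon bound to two saturated chain carbons and it puts 2,4,6-trimethylphenyl in place of thiophen-2-yl on a saturated chain carbon bound to two saturated chain carbons.

Going by the values given here, no measured pair differs in just one place, so the data show no step of this kind. Among the compounds with values here, at most a small step towards measurable inhibition is expected in this assay for this change, since compound 3 reaches only 50000 nM as the one number available. For compound 4 the estimated value is 50000 nM, with an expected range from 20000 nM to 120000 nM, although a report of no activity is also expected to be quite possible.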

Compound 4, half-maximal inhibitory concentration: 28800 nM
The estimate for compound 4 lay 1.7-fold (0.24 log units) above the measured number; the measured number falls inside the stated range.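

Compound 2 is reported as not active in this assay and has no number, so the change to compound 4, which gives 28800 nM, cannot be read as a step. The compounds shown leave open how much of that value comes from 2,4,6-trimethylphenyl in place of thiophen-2-yl, and nothing measured here gives a reason for it.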